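This account rests on a few compounds, and the source may have more. Where it says the series, first, only, none or still open, it means among the compounds named here.

Compound 1 `Clc1ccccc1CSc1nnc(-c2ccc3c(c2)OCCO3)n1-c1ccccc1` carries the shared core with a (2-chlorobenzyl)sulfanyl group, and in a functional assay on HeLa cells (Homo sapiens) for antiproliferative activity, read by MTT assay, with a stated time of 24 h (on this read-out lower numbers stand for stronger inhibition and higher numbers for weaker inhibition), compound 1 gives 29000 nM. Compound 3 `Fc1ccccc1CSc1nnc(-c2ccc3c(c2)OCCO3)n1-c1ccccc1`, the fluoro analogue, gives 24300 nM in this assay, so the step of a 1.2-fold lower number from compound 1 to compound 3 (0.08 log units; within the scatter) is within the scatter and the two cannot be ordered. Compound 2 `COc1cccc(CSc2nnc(-c3ccc4c(c3)OCCO4)n2-c2ccccc2)c1` reaches only a limit of this assay, > 100000 nM, as noted in the limit of > 100000 nM in this assay, at which 1 of the 3 values shown sits. Among the numbers shown, compound 1 stands highest of the two, with compound 3 its nearest neighbour. Compound 4 `Brc1cccc(CSc2nnc(-c3ccc4c(c3)OCCO4)n2-c2ccccc2)c1` is not yet measured; its change from compound 1 is 3-bromophenyl in place of 2-chlorophenyl on a saturated chain carbon bound to a sulfur. Among the measured compounds shown here, the steps that bear on it are an at least 3.4-fold higher number from compound 1 to compound 2 (0.53 log units; beyond the scatter) and an at least 4.1-fold lower number from compound 2 to compound 3 (0.61 log units; beyond the scatter), both at least modest and both pointing the same way: a 3-methoxyphenyl on that chain carbon sits at the limit, while 2-chlorophenyl and 2-fluorophenyl give numbers. Compound 4 is therefore expected to move toward weaker inhibition, by about a 2.1-fold higher number from compound 1 to compound 4 (0.32 log units; beyond the scatter), and compound 4 is estimated at 60000 nM, within 20000 nM to 150000 nM.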

Compound 4, half-maximal inhibitory concentration: 44200 nM
For compound 4 the middle estimate is 1.4-fold (0.13 log units) above the measured one; the measured number falls inside the stated range.
By their numbers in this assay, from the lowest: compounds 3, 1 and 4 (each within the scatter of the next). At a limit, above all of these: compound 2.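

In this assay, 3-bromophenyl on a saturated chain carbon bound to a sulfur gives a 1.5-fold higher number from compound 1 to compound 4 (0.18 log units; within the scatter) and a 1.8-fold higher number from compound 3 to compound 4 (0.26 log units; within the scatter), so this change of both halogen and ring position does not separate these compounds. Bromo in place of methoxy on an aromatic carbon gives an at least 2.2-fold lower number from compound 2 to compound 4 (0.35 log units; beyond the scatter), which shows that the earlier gap between 3-methoxyphenyl and the two 2-halogenated groups does not extend to 3-bromophenyl. Compound 2 itself remains a limit and not a number: the limit of > 100000 nM in this assay, at which 1 of the 4 values shown sits.

As far as these compounds go, whether the halogen or its ring position governs the number stays open, and a 2-bromophenyl or 3-chlorophenyl group would bear on that. From the compounds shown here alone, how an amine, a carboxylic acid or a longer chain at this place would read in this assay also remains open.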